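A few compounds are considered here, and "the series" means these few. Any claim that something is new, unique, unknown or untested is made for them only; others in the source may bear on it.

In an assay on BaF3 cells with thrombopoietin receptor (Homo sapiens) as the target, read by a luciferase reporter (a higher number here means a larger maximal response, a lower number a smaller maximal response), three compounds have been measured. Compound 1 `Cc1[nH]n(C(C)(C)C)c(=O)c1/N=N/c1c(O)cc(S(=O)(=O)O)c2ccccc12` sits at a limit of the assay, < 5%, and not at a number (the limit of < 5% in this assay, at which 1 of the 3 values shown sits). Compound 2 `Cc1[nH]n(-c2cccc(C(F)(F)F)c2)c(=O)c1/N=N/c1c(O)cc(S(=O)(=O)O)c2ccccc12` gives 62%. Compound 3 `Cc1[nH]n(-c2ccc(C(C)(C)C)cc2)c(=O)c1/N=N/c1c(O)cc(S(=O)(=O)O)c2ccccc12` gives 86%, the higher of the two numbers and the top value among all three. Every measured step changes the group on the aromatic nitrogen: a number at least 57 percentage points higher from compound 1 to compound 2 (beyond the scatter), a number at least 81 percentage points higher from compound 1 to compound 3 (beyond the scatter) and a number 24 percentage points higher from compound 2 to compound 3 (beyond the scatter). Compound 4 `CC(C)(C)c1ccc(-n2[nH]c(C(=O)O)c(/N=N/c3c(O)cc(S(=O)(=O)O)c4ccccc34)c2=O)cc1` differs from compound 3 at another position: carboxy in place of methyl on an aromatic carbon. Among the measured compounds shown here, none of the measured steps touches this aromatic carbon, so they give no direct guide to the size or direction of the change; they show only that changes to the shared core can move this assay strongly. For compound 4 the expected step is a number 26 percentage points lower from compound 3 to compound 4 (beyond the scatter), with wide uncertainty in both directions. Compound 4 is estimated to reach 60%, within a range from 20% to 95%.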

Compound 4, largest response reached (reported as efficacy), in percent of the reference or control that the assay uses: < 5%
Compound 4: no number, only a limit; the forecaster's own chance of this, stated with the estimate: 15%; middle value at least 55 percentage points from the limit.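

In this assay, carboxy in place of methyl on this aromatic carbon gives a number at least 81 percentage points lower from compound 3 to compound 4 (beyond the scatter). Among the compounds shown here, this carbon, which no earlier step touched, therefore matters to the response as well as the group on the aromatic nitrogen, and keeping the 4-(tert-butyl)phenyl group does not by itself secure a response. Compound 4 stands at a limit of the assay and not at a number, so the true size of the loss stays unknown: the limit of < 5% in this assay, at which 2 of the 4 values shown sit.

With only methyl and carboxy shown at this carbon, it stays open whether any larger group here loses the response or only carboxy does; an ethyl group, a methyl ester or a primary amide at this carbon would help separate these cases. As far as these compounds go, it is also open whether the same change would act alike with the 3-(trifluoromethyl)phenyl group of compound 2.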